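The compounds below may be only part of what the source reports. "The series", "measured", "known", "first", "only" and "open" are said of these compounds alone.

Series notes. Compound 1 `Fc1ccc(Cc2ccc3c(NCCCNCc4ccco4)ccnc3c2)cc1` carries a furan-2-yl group on the amine side chain; in an ADME assay for permeability, using PAMPA, with a stated time of 30 min, at pH 7.4 (on this read-out higher numbers stand for higher permeability and lower numbers for lower permeability), compound 1 gives 23 10^-6 cm/s. Compound 2 `COc1cccc(CNCCCNc2ccnc3cc(Cc4ccc(F)cc4)ccc23)c1O` differs from compound 1 only by 2-hydroxy-3-methoxyphenyl in place of furan-2-yl on a saturated chain carbon bound to an amine nitrogen. In this assay compound 2 gives 23 10^-6 cm/s, and the step reads no change at the digits printed from compound 1 to compound 2 (within the scatter). Compound 3 `FC(F)(F)c1cc(-c2ccc3c(NCCCNCc4ccco4)ccnc3c2)cc(C(F)(F)F)c1` keeps the furan-2-yl side chain of compound 1 on a different core; how the two cores differ is not broken down here. In this assay compound 3 gives 237 10^-6 cm/s, the highest of the three measured numbers, and its gap to compound 1 and to compound 2 lies beyond the scatter in each case.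

Compound 4 `COc1cccc(CNCCCNc2ccnc3cc(-c4cc(C(F)(F)F)cc(C(F)(F)F)c4)ccc23)c1O` is not yet measured. It stands to compound 3 as compound 2 stands to compound 1: 2-hydroxy-3-methoxyphenyl in place of furan-2-yl on a saturated chain carbon bound to an amine nitrogen. The place is the same word for word in both pairs, so this is the same change carried onto the core of compound 3. Going by the values given here, the only precedent for this change reads no change at the digits printed from compound 1 to compound 2 (within the scatter). On that basis the step is expected to be a 1.1-fold lower number from compound 3 to compound 4 (0.03 log units; within the scatter), essentially flat. Compound 4 is therefore estimated at 220 10^-6 cm/s in this assay, within 100 10^-6 cm/s to 450 10^-6 cm/s. A single precedent holds this estimate loosely; whether the change reads the same on a second core is what the measurement will show.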

Compound 4, apparent permeability: 237 10^-6 cm/s
For compound 4 the middle estimate is 1.1-fold (0.03 log units) below the measured one; the range from low to high includes it.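

Working notes on the side chain. In this assay, putting 2-hydroxy-3-methoxyphenyl in place of furan-2-yl on a saturated chain carbon bound to an amine nitrogen reads no change at the digits printed from compound 3 to compound 4 (within the scatter), so the second core repeats the flat reading of the first, and the two steps do not differ beyond what repeated measurements would give: the same change on two cores in this assay, no change at the digits printed (within the scatter) from compound 1 to compound 2 and no change at the digits printed (within the scatter) from compound 3 to compound 4, 1.0-fold (0.00 log units) apart, within the scatter of two such steps Within this series, the exchange of these two groups can therefore be carried from the core of compound 1 to the core of compound 3 with no visible change in the read-out. This rests on two pairs only: it sets no rule for any further core, it does not say why the read-out stays flat, and it does not show that the larger group, with its added hydrogen-bond donor, would leave the read-out flat in any other setting.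

Still open, as far as these compounds go, is whether the same flat reading holds for other groups at this place, such as a plain phenyl, a pyridine ring or a carboxylic acid, or for a longer chain on the amine side. Also open, from the compounds shown here alone, is whether it survives on a third core, and whether the exchange reads the same in any measurement other than this assay.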